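Swapping a hexyl chain for 4-fluorophenyl on the side chain

The compounds below may be only part of what the source reports. "The series", "measured", "known", "first", "only" and "open" are said of these compounds alone.

Compounds measured so far:
- compound 1, `Oc1cccc(/C=C/C[C@H]2C[C@@H]([C@@H](O)c3ccccc3)CO[C@@H]2c2ccccc2)c1`, gives 18600 nM
- compound 2, `COc1cccc(/C=C/C[C@H]2C[C@@H]([C@@H](O)c3ccccc3)CO[C@@H]2c2ccccc2)c1`, gives 10900 nM
- compound 3, `CCCCCC/C=C/C[C@H]1C[C@@H]([C@@H](O)c2ccccc2)CO[C@@H]1c1ccccc1`, gives 7400 nM

All three numbers come from a functional assay on HeLa cells (Homo sapiens) for cytotoxicity, read by WST assay, with a stated time of 48 h; on this read-out lower numbers stand for stronger inhibition and higher numbers for weaker inhibition. Compound 3 has the lowest of the three, though compound 2 sits within the scatter of it, so no ranking between those two can be drawn; only compound 1 is clearly apart, as a 2.5-fold lower number from compound 1 to compound 3 (0.40 log units; beyond the scatter) shows.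

Compound 4, `O[C@@H](c1ccccc1)[C@H]1CO[C@H](c2ccccc2)[C@@H](C/C=C/c2ccc(F)cc2)C1`, differs from compound 3 in one place: 4-fluorophenyl in place of hexyl on a double-bonded chain carbon bound to a double-bonded chain carbon. This puts an aromatic ring back where compounds 1 and 2 carried one, so the steps of a 2.5-fold lower number from compound 1 to compound 3 (0.40 log units; beyond the scatter) and a 1.5-fold lower number from compound 2 to compound 3 (0.17 log units; within the scatter) bear on it, and each ran toward a lower number when the aryl group gave way to hexyl. The step of a 1.7-fold lower number from compound 1 to compound 2 (0.23 log units; within the scatter) also shows that changing the group on that ring moved the number only within the scatter.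

Reversing the change is therefore expected to give compound 4 a somewhat higher number than compound 3, in the step of a 1.5-fold higher number from compound 3 to compound 4 (0.17 log units; within the scatter), perhaps not clearly beyond the scatter. Compound 4 is estimated at 11000 nM, in the range 5500 nM to 22000 nM.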

Compound 4, half-maximal inhibitory concentration: 8340 nM
The estimate for compound 4 lay 1.3-fold (0.12 log units) above the measured number, and the stated range covers the measured number.
By their numbers in this assay, from the lowest: compounds 3, 4, 2 and 1 (each within the scatter of the next, the first and the last beyond it).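

In this assay, putting 4-fluorophenyl in place of hexyl on a double-bonded chain carbon bound to a double-bonded chain carbon gives a 1.1-fold higher number from compound 3 to compound 4 (0.05 log units; within the scatter), so at this position an aromatic ring and a chain with no ring cannot be told apart, and the upward shift expected for an aromatic ring does not appear. Among the three aromatic groups the picture is less clean: a 2.2-fold lower number from compound 1 to compound 4 (0.35 log units; beyond the scatter) lies beyond the scatter while a 1.3-fold lower number from compound 2 to compound 4 (0.12 log units; within the scatter) lies within it, and compound 2 does not separate clearly from compound 1 either, so only the 3-hydroxyphenyl group of compound 1 stands apart from hexyl and 4-fluorophenyl, and compound 2 blurs that split. Nothing available here explains these numbers.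

It remains open whether the fluorine contributes anything, since an unsubstituted phenyl ring is not among these compounds, and whether a longer chain than hexyl would move the number beyond the scatter. An amine or a carboxylic acid in this place is also not represented, so the range of groups shown here may not reveal how far this position can shift the number.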